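Methyl in place of methoxy: compound 1 to compound 4

The source may report more compounds than this note shows. Statements on the series, on what has been measured and on what is new or still open speak of the compounds shown alone.

compound 1 `COc1ccc(-c2nc3c(NC4CCCC4)ncnc3n2C)cc1`: 1850 nM in an assay on CHO cells for displacement of a labelled ligand from adenosine receptor A3 (Homo sapiens), read by scintillation counting, with a stated time of 3 h; a lower number here means a stronger inhibitor, a higher number a weaker inhibitor
compound 2 `CCCn1c(-c2ccccc2)nc2c(NC3CCC3)ncnc21`: 264 nM in this assay
compound 3 `CCCn1c(-c2ccccc2)nc2c(NC3CCCC3)ncnc21`: 749 nM in this assay

Compound 1 stands at the highest number of the three; compound 3 lies below it beyond the scatter, compound 2 further still. Compound 4 `Cc1ccc(-c2nc3c(NC4CCCC4)ncnc3n2C)cc1` differs from compound 1 by methyl in place of methoxy on an aromatic carbon. Going by the values given here, the one step measured so far, a 2.8-fold higher number from compound 2 to compound 3 (0.45 log units; beyond the scatter), alters the ring on the amine nitrogen and leaves the substituent on the phenyl ring untouched, so it does not bear on this change. Among the compounds with values here, no measured pair varies the group on the phenyl ring. With nothing in the series arguing for a shift in either direction, compound 4 is expected to stay within the scatter of compound 1, a 1.2-fold lower number from compound 1 to compound 4 (0.06 log units; within the scatter). The estimate for compound 4 is 1600 nM, in a range from 600 nM to 4500 nM.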

Compound 4, inhibition constant: 480 nM
Estimate against measurement, compound 4: 3.3-fold (0.52 log units) above, and the stated range ends above it.
By their numbers in this assay, from the lowest: compounds 2, 4 and 3 (each within the scatter of the next, the first and the last beyond it); then compound 1.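

Going by these compounds alone, the group on the phenyl ring matters in this assay: 4-methoxyphenyl to 4-methylphenyl gives a 3.9-fold lower number from compound 1 to compound 4 (0.59 log units; beyond the scatter) and is the first measured change at this position. The step exchanges methoxy, a hydrogen-bond acceptor, for methyl, which is not one, but this single pair cannot separate the loss of the acceptor from any other difference between the two groups. No measurement shown accounts for the step.

Open, as far as these compounds go, is how an unsubstituted phenyl, chloro, ethyl or hydroxy would compare at this position with the same cyclopentylamino group and methyl on the core. Also open, from the compounds shown here alone, is whether the step carries over to the propyl-bearing core of compound 3.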